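This account rests on a few compounds, and the source may have more. Where it says the series, first, only, none or still open, it means among the compounds named here.

In an ADME assay on HepG2 cells (Homo sapiens) for inhibition, read by luminescence and CellTiter-Glo, with stated times of 24 h and 48 h (a higher number here means a weaker inhibitor, a lower number a stronger inhibitor), compound 1 `CNC(=O)CN(Cc1ccc(C(=O)NO)cc1)C(=O)c1ccc(C(C)C)cc1` gives 9160 nM, a true measured number. Compound 2 `CC(C)c1ccc(C(=O)N(Cc2ccc(C(=O)NO)cc2)C(C)(C)C(=O)NC2CCCCC2)cc1` gives > 50000 nM, which is a limit of the assay and not a number. Compound 3 `CN(C)c1ccc(C(=O)N(Cc2ccc(C(=O)NO)cc2)C(C)(C)C(=O)NCc2ccccc2)cc1` gives > 50000 nM, which is also a limit and not a number. That places compound 3 at the limit of > 50000 nM in this assay, at which 2 of the 3 values shown sit.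

Compound 4 `CC(C)c1ccc(C(=O)N(Cc2ccc(C(=O)NO)cc2)C(C)(C)C(=O)NCc2ccccc2)cc1` has not yet been measured. It differs from compound 3 in one place, with isopropyl in place of dimethylamino on an aromatic carbon. Going by the values given here, no measured pair of compounds differs in one place only, so the size of this change cannot be read directly from the data.

Compound 2 also carries the 4-isopropylphenyl group and gives > 50000 nM, a limit, which suggests that this group alone need not bring a number within range. No change beyond the usual scatter is expected in either direction. The estimated step of a number no higher from compound 3 to compound 4 (the limit leaves the size open) is therefore small. Compound 4 is expected at 50000 nM, with an estimated range of 20000 nM to 100000 nM.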

Compound 4, half-maximal inhibitory concentration: > 50000 nM
Compound 4 was reported as a limit (the forecaster's own chance of this, stated with the estimate: 65%); the middle value sits exactly at the limit.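

Compound 2, compound 3 and compound 4 are all reported only as a limit, so no step from compound 3 or compound 2 to compound 4 can be read: the limit of > 50000 nM in this assay, at which 3 of the 4 values shown sit.

Left open is whether isopropyl and dimethylamino, or benzyl and cyclohexyl, differ at all in this assay.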